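This account rests on a few compounds, and the source may have more. Where it says the series, first, only, none or still open, it means among the compounds named here.

Going by the values given here, in an ADME assay on microsomes from liver (Homo sapiens) for metabolic stability, read by LC-MS, with a stated time of 10 min, tested at 0.5 uM (on this read-out higher numbers stand for a more stable compound and lower numbers for a less stable compound), compound 1 `c1ccc2c(c1)CN[C@@H](CN(CC1CCNCC1)[C@H]1CCCc3cccnc31)C2` gives 86% as the higher of the two numbers so far, while compound 2 `CN1CCN(CCCN(C[C@H]2Cc3ccccc3CN2C)[C@H]2CCCc3cccnc32)CC1` gives 60% at a distance beyond the usual scatter. Compound 3 `c1ccc2c(c1)CN[C@@H](CN(CCN1CCNCC1)[C@H]1CCCc3cccnc31)C2` is still unmeasured. Among the compounds with values here, its change from compound 1 is (piperazin-1-yl)methyl in place of piperidin-4-yl on a saturated chain carbon bound to an amine nitrogen and no measured pair isolates this change. A small fall in this assay is expected, possibly within the scatter, and the estimated a number 8 percentage points lower from compound 1 to compound 3 (within the scatter) remains tentative. Compound 3 is estimated at 78% with an expected range of 62% to 92% until measured.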

Compound 3, percent of the compound remaining: 96%
Compound 3: the middle estimate sits 18 percentage points below what was measured, outside the stated range (above it).
By their numbers in this assay, from the lowest: compound 2; then compounds 1 and 3 (each within the scatter of the next).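

In this assay, going by these compounds alone, the one pair that isolates this position shows a number 10 percentage points higher from compound 1 to compound 3 (within the scatter), so (piperazin-1-yl)methyl can stand in place of piperidin-4-yl on a saturated chain carbon bound to an amine nitrogen with no step beyond the scatter. With the shared core held constant, this single change leaves the read-out indistinguishable between the two compounds. No measurement at hand accounts for this result.

Still open, on these data alone, is how a carboxylic acid or a dimethylamino group would read at this position. A single pair also leaves open whether the result holds on another core.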